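One Ring Swapped: 1,3-Thiazol-2-yl to Thiophen-3-yl

The compounds below may be only part of what the source reports. "The series", "measured", "known", "first", "only" and "open" are said of these compounds alone.

Of the compounds shown here, three with a shared core have been tested in a functional assay on HL-60 cells (Homo sapiens) for inhibition (a higher number here means a weaker inhibitor, a lower number a stronger inhibitor), and they differ only in the aromatic ring attached to that core. Compound 1 `OC[C@H]1OC(n2cnc3c(-c4ccco4)ncnc32)[C@H](O)[C@@H]1O`, carrying furan-2-yl, gives 2700 nM. Compound 2 `OC[C@H]1OC(n2cnc3c(-c4ccc(F)cc4)ncnc32)[C@H](O)[C@@H]1O`, carrying 4-fluorophenyl, gives 6300 nM. Compound 3 `OC[C@H]1OC(n2cnc3c(-c4nccs4)ncnc32)[C@H](O)[C@@H]1O`, carrying 1,3-thiazol-2-yl, gives 6300 nM. This places compound 3 level with compound 2, and both are weaker inhibitors than compound 1.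

Compound 4 `OC[C@H]1OC(n2cnc3c(-c4ccsc4)ncnc32)[C@H](O)[C@@H]1O` has thiophen-3-yl in place of 1,3-thiazol-2-yl on an aromatic carbon. Going by the values given here, no measured compound carries thiophen-3-yl, so the evidence is indirect. The closest comparison is another exchange of one five-membered ring for another, which gave a 2.3-fold higher number from compound 1 to compound 3 (0.37 log units; beyond the scatter). Exchanging furan-2-yl for 4-fluorophenyl gave a 2.3-fold higher number from compound 1 to compound 2 (0.37 log units; beyond the scatter), and exchanging 4-fluorophenyl for 1,3-thiazol-2-yl gave no change at the digits printed from compound 2 to compound 3 (within the scatter). Among these three compounds, ring exchanges have therefore produced modest steps at most. The expected result is a 1.4-fold lower number from compound 3 to compound 4 (0.15 log units; within the scatter), an estimated step that stays within the scatter. For compound 4, the estimated value is 4500 nM, with an expected range of 1800 nM to 11000 nM.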

Compound 4, half-maximal inhibitory concentration: 3800 nM
The estimate for compound 4 lay 1.2-fold (0.07 log units) above the measured number; the range from low to high includes it.
By their numbers in this assay, from the lowest: compounds 1, 4, 2 and 3 (each within the scatter of the next, the first and the last beyond it).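

Swapping 1,3-thiazol-2-yl for thiophen-3-yl takes one hetero atom out of the ring and one hydrogen-bond acceptor with it, yet the result is a 1.7-fold lower number from compound 3 to compound 4 (0.22 log units; within the scatter) and so cannot be told apart from no effect in this assay. The same holds against the two other rings, with a 1.7-fold lower number from compound 2 to compound 4 (0.22 log units; within the scatter) and a 1.4-fold higher number from compound 1 to compound 4 (0.15 log units; within the scatter) as the readings. Compound 4 therefore sits within the scatter of all three earlier compounds, including compound 1 and compound 3, which lie beyond the scatter of each other, so the gap between those two is too small for a ring placed at this aromatic carbon to be ranked firmly, and the four rings together span only a narrow band.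

No measurement at hand explains why these rings read so alike. As far as these compounds go, all four compounds place an aromatic ring directly on this carbon, so it remains open what an amine, a carboxylic acid or a longer alkyl chain would do there, and whether any such group would move the number well beyond the scatter in either direction.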